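Methylating the Phenol of Compound 3

The source may report more compounds than this note shows. Statements on the series, on what has been measured and on what is new or still open speak of the compounds shown alone.

Compound 3 `COc1cc(-c2nn(-c3ccccc3)cc2C(=O)/C=C\Nc2ccc(O)cc2)cc(OC)c1OC` gives in a functional assay on U-87MG ATCC cells (Homo sapiens) for antiproliferative activity, read by MTT assay, with a stated time of 48 h (a higher number here means a weaker inhibitor, a lower number a stronger inhibitor), a value of 1800 nM, the lowest of the two numbers shown. Compound 1 `COc1ccc(N/C=C\C(=O)c2cn(-c3ccccc3)nc2-c2ccc(Cl)cc2)cc1` gives 6890 nM in this assay. Compound 2 `COc1ccc(N/C=C\C(=O)c2cn(-c3ccccc3)nc2-c2ccc(OC)cc2)cc1` reaches only a limit of this assay, > 50000 nM (the limit of > 50000 nM in this assay, at which 1 of the 3 values shown sits). For the measured compounds named here, the single measured step, an at least 7.2-fold higher number from compound 1 to compound 2 (0.86 log units; beyond the scatter), concerns the change of chloro to methoxy on an aromatic carbon and says nothing about the phenol oxygen.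

Compound 4 `COc1ccc(N/C=C\C(=O)c2cn(-c3ccccc3)nc2-c2cc(OC)c(OC)c(OC)c2)cc1` differs from compound 3 by methyl in place of hydrogen on an oxygen on an aromatic ring. Going by the values given here, compound 1 and compound 2 already carry the (4-methoxyphenyl)amino group of compound 4, yet no measured pair isolates the hydroxy-to-methoxy exchange, so the step from compound 3 is expected to be small, with no direction beyond the scatter clearly favoured. The estimate for compound 4 in this assay is 3000 nM, within a range of 900 nM to 12000 nM, which amounts to an expected step of a 1.7-fold higher number from compound 3 to compound 4 (0.22 log units; within the scatter).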

Compound 4, half-maximal inhibitory concentration: 12800 nM
Beside the measured number, compound 4's estimate is 4.3-fold (0.63 log units) below it; the measured number lies above the stated range.
By their numbers in this assay, from the lowest: compound 3; then compounds 1 and 4 (each within the scatter of the next). At a limit, above all of these: compound 2.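

In this assay, the exchange of hydroxy for methoxy on this aromatic ring now has a direct reading, a 7.1-fold higher number from compound 3 to compound 4 (0.85 log units; beyond the scatter), which shows that this oxygen is not indifferent to a methyl and that the free hydroxy goes with the lower number. With the (4-methoxyphenyl)amino group held constant, the other aryl changes read as a 1.9-fold higher number from compound 1 to compound 4 (0.27 log units; within the scatter) and an at least 3.9-fold lower number from compound 2 to compound 4 (0.59 log units; beyond the scatter), so 3,4,5-trimethoxyphenyl does not separate from 4-chlorophenyl but does separate from 4-methoxyphenyl. Compound 2 stands at a limit, so the last step is only a bound: the limit of > 50000 nM in this assay, at which 1 of the 4 values shown sits.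

Compound 3 is the only compound shown with the free hydroxy, so it stays open whether the hydroxy keeps its advantage with 4-chlorophenyl in place of 3,4,5-trimethoxyphenyl. From the compounds shown here alone, how an amine, a carboxylic acid or an ethoxy group would read at this position also remains open.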